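A Dichlorophenyl Swap on a Trimethoxyphenyl Oxadiazoline

The source may report more compounds than this note shows. Statements on the series, on what has been measured and on what is new or still open speak of the compounds shown alone.

Of the compounds shown here, three have been tested in a functional assay on BGC-823 cells (Homo sapiens) for antiproliferative activity, read by MTT assay, tested at 5 uM; a lower number here means a weaker effect, a higher number a stronger effect of the compound at the concentration tested. Compound 1 `COc1ccc(/C=N/NC(=O)c2cc(OC)c(OC)c(OC)c2)c(OC)c1` gives 3.6%. Compound 2 `COc1cc(C2=NN(C(C)=O)C(c3ccccc3C(F)(F)F)O2)cc(OC)c1OC` gives 34.8%, the highest of the three numbers. Compound 3 `COc1cc(C(=O)N/N=C/c2ccc(Cl)c(Cl)c2)cc(OC)c1OC` gives 32.7%, which lies within the scatter of compound 2, while compound 1 lies far below it. Compound 4 `COc1cc(C2=NN(C(C)=O)C(c3ccc(Cl)c(Cl)c3)O2)cc(OC)c1OC` has not been measured. It differs from compound 2 in one place: 3,4-dichlorophenyl in place of 2-(trifluoromethyl)phenyl on a saturated ring carbon. Among the compounds with values here, no measured pair shows this change on the shared core, so no step size is known from experiment. Compound 3 carries a 3,4-dichlorophenyl group on a different core and gives 32.7%, close to compound 2 with 34.8%. Given that, the step of a number 0.2 percentage points higher from compound 2 to compound 4 (within the scatter) is expected to stay within the scatter. Compound 4 is estimated at 35%, likely between 20% and 50%.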

Compound 4, a percentage reported as inhibition, at one concentration (the size of the read-out at that concentration, not a potency): 3.1%
The estimate for compound 4 lay 31.9 percentage points above the measured number; measured number below the stated range.
By their numbers in this assay, from the lowest: compounds 4 and 1 (each within the scatter of the next); then compounds 3 and 2 (each within the scatter of the next).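

In this assay, placing 3,4-dichlorophenyl instead of 2-(trifluoromethyl)phenyl on the saturated ring carbon gives a number 31.7 percentage points lower from compound 2 to compound 4 (beyond the scatter). Within the data shown here, this is the first step measured at this position, and it shows that exchanging one substituted phenyl group for another here can change the result strongly on the shared core. No measurement at hand explains the drop. Still open, going by these compounds, is whether the difference comes from losing 2-(trifluoromethyl)phenyl or from adding 3,4-dichlorophenyl. Also open, on these data alone, is how an unsubstituted phenyl group, or a phenyl group carrying an amine or a carboxylic acid, would behave at this position.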